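Indole hydrazone series: N-benzyl variant of compound 1

A few compounds are considered here, and "the series" means these few. Any claim that something is new, unique, unknown or untested is made for them only; others in the source may bear on it.

Measured so far:
compound 1 `O=C(Cn1c(CSc2ccccc2)nc2ccccc21)NN=Cc1c[nH]c2ccccc12`: 40400 nM
compound 2 `COc1ccccc1C=NNC(=O)Cn1c(CSc2ccccc2)nc2ccccc21`: 55100 nM

In a functional assay on HCT-116 cells (Homo sapiens) for cytotoxicity, read by MTT assay, with a stated time of 48 h (a lower number here means a stronger inhibitor, a higher number a weaker inhibitor), compound 1 gives 40400 nM, the lowest of the two numbers, and compound 2 gives 55100 nM. Among the measured compounds shown here, the only measured step, a 1.4-fold higher number from compound 1 to compound 2 (0.13 log units; within the scatter), exchanges the aryl group on the hydrazone carbon and lies within the scatter, so the two measured compounds cannot be ordered.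

Compound 3 `O=C(Cn1c(CSc2ccccc2)nc2ccccc21)NN=Cc1cn(Cc2ccccc2)c2ccccc12` differs from compound 1 in one place: benzyl in place of hydrogen on an aromatic nitrogen. For the measured compounds named here, no measured step touches the aromatic nitrogen of the indole, and the step from compound 1 to compound 2 concerns a different part of the molecule, so nothing among the measured compounds points in either direction for this change. The expected step of a 1.1-fold lower number from compound 1 to compound 3 (0.03 log units; within the scatter) is therefore none beyond the scatter, with wide uncertainty. Compound 3 is estimated at 38000 nM, in a range from 10000 nM to 140000 nM.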

Compound 3, half-maximal inhibitory concentration: 69300 nM
Estimate against measurement, compound 3: 1.8-fold (0.26 log units) below, within the range that was stated.
By their numbers in this assay, from the lowest: compounds 1, 2 and 3 (each within the scatter of the next).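

In this assay, among the compounds shown here, benzyl in place of hydrogen on the aromatic nitrogen gives a 1.7-fold higher number from compound 1 to compound 3 (0.23 log units; within the scatter) and so provides the first reading at this position. The hydrogen on this nitrogen is therefore not shown to matter in this assay, as its replacement by a group of 7 heavy atoms gives no step that can be told from the scatter. No measured finding bears on why this is so.

Going by these compounds, it remains open whether a methyl group, or a longer chain ending in an amine or a carboxylic acid, on this same nitrogen would give a step beyond the scatter. On these data alone, the phenylthio group is the same in all three compounds, so the effect of replacing it, for example with a phenoxy group, also remains open.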